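Second oxiranylmethyl ether on the shared chromone core

The source may hold more compounds than are shown below. What is called first, only, known or untested is meant among the compounds shown, and "the series" means these compounds.

Compound 2 `Cc1cc(=O)c2c(O)cc(OC[C@H]3CO3)cc2o1` gives 22900 nM in a functional assay on MCF7 cells (Homo sapiens) for antiproliferative activity, with a stated time of 48 h; a higher number here means a weaker inhibitor, a lower number a stronger inhibitor. Compound 1 `Cc1cc(=O)c2c(O)cc(OCC3CO3)cc2o1` gives 13600 nM in this assay and compound 3 `Cc1cc(=O)c2c(O)cc(OC[C@@H]3CO3)cc2o1` gives 36200 nM in this assay. The steps of a 1.7-fold higher number from compound 1 to compound 2 (0.23 log units; within the scatter) and a 1.6-fold higher number from compound 2 to compound 3 (0.20 log units; within the scatter) both stay within the scatter, so compound 2 cannot be set apart from either neighbour; only a 2.7-fold higher number from compound 1 to compound 3 (0.43 log units; beyond the scatter) reaches beyond it, and that step rests on the fact that one of compounds 1 and 3 is drawn with a defined configuration and the other without, at the place where they differ alone.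

Compound 4 `Cc1cc(=O)c2c(OC[C@@H]3CO3)cc(OC[C@H]3CO3)cc2o1` differs from compound 2 by (oxiran-2-yl)methyl in place of hydrogen on an oxygen on an aromatic ring. Among the measured compounds shown here, no measured step bears on this change: the three known steps concern configuration at the ring carbon only, as the fact that one of compounds 1 and 2 is drawn with a defined configuration and the other without, at the place where they differ and the fact that compounds 2 and 3 differ only in the configuration as drawn show, and none replaces a hydrogen on an aromatic oxygen with a second ether. The expectation in this assay is therefore anchored on compound 2 with a wide band and no direction beyond the scatter. Compound 4 is estimated at 20000 nM in this assay, from 6000 nM to 65000 nM. The expected step is a 1.1-fold lower number from compound 2 to compound 4 (0.06 log units; within the scatter).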

Compound 4, half-maximal inhibitory concentration: 13900 nM
Compound 4: the middle estimate sits 1.4-fold (0.16 log units) above what was measured, and the stated range covers the measured number.
By their numbers in this assay, from the lowest: compounds 1, 4, 2 and 3 (each within the scatter of the next, the first and the last beyond it).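

In this assay, (oxiran-2-yl)methyl in place of hydrogen on an oxygen on an aromatic ring gives a 1.6-fold lower number from compound 2 to compound 4 (0.22 log units; within the scatter). The hydrogen on this oxygen can therefore be replaced by this group without a step beyond the scatter, and compound 4, with its second (oxiran-2-yl)methyl, cannot be set apart from compound 2. The observations at hand on configuration do not bear on this replacement and offer no explanation for the result.

Only this one replacement at the oxygen is shown, so it remains open whether a methyl ether, a longer alkyl chain or a chain ending in an amine would give a step beyond the scatter. Also open, going by these compounds, is how the opposite configuration of the entering (oxiran-2-yl)methyl would read in this assay.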